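Dropping one fluorine from a sulfonamide aryl group

This account rests on a few compounds, and the source may have more. Where it says the series, first, only, none or still open, it means among the compounds named here.

Measured compounds:
- compound 1, `CCOC(=O)c1cnc2ccc(-c3cnc(OC)c(NS(=O)(=O)c4ccc(F)cc4F)c3)cn12`: 120 nM
- compound 2, `CCOC(=O)c1cc2cc(-c3cnc(OC)c(NS(=O)(=O)c4ccc(F)cc4)c3)ccc2[nH]1`: 150 nM

Both values come from a functional assay on MDA-MB-231 cells (Homo sapiens) for antiproliferative activity, read by sulforhodamine B assay, with a stated time of 72 h; on this read-out lower numbers stand for stronger inhibition and higher numbers for weaker inhibition. Compound 1 gives 120 nM and compound 2 gives 150 nM; the two numbers lie within the usual scatter of each other, so neither compound can be called the stronger, and compound 1 simply gives the smaller of the two numbers. The two compounds also differ in their core, so no single change links them.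

Compound 3, `CCOC(=O)c1cnc2ccc(-c3cnc(OC)c(NS(=O)(=O)c4ccc(F)cc4)c3)cn12`, keeps the core of compound 1 and alters only the sulfonamide aryl group: hydrogen in place of fluoro on an aromatic carbon. The change takes place on an aromatic carbon of a six-membered aromatic ring of carbon only, ortho to a large group and meta to a fluoro group; read one bond further out, it turns 2,4-difluorophenyl into 4-fluorophenyl.

Among the measured compounds shown here, no measured pair shows this step directly. Compound 2 carries the same 4-fluorophenyl group on another core and gives 150 nM, which suggests a small effect. The step from compound 1 to compound 3 is therefore expected to be a 1.3-fold higher number from compound 1 to compound 3 (0.10 log units; within the scatter), a shift not beyond the scatter. Compound 3 is estimated at 150 nM, with a likely range from 60 nM to 400 nM.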

Compound 3, half-maximal inhibitory concentration: 530 nM
Compound 3: middle estimate off by 3.5-fold (0.55 log units), on the low side; measured number outside the range, above it.
By their numbers in this assay, from the lowest: compounds 1 and 2 (each within the scatter of the next); then compound 3.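

In this assay, putting hydrogen in place of fluoro on this aromatic carbon, ortho to a large group and meta to a fluoro group, gives a 4.4-fold higher number from compound 1 to compound 3 (0.65 log units; beyond the scatter) on the core of compound 1. So on this core, the change from 2,4-difluorophenyl to 4-fluorophenyl is a real step rather than a shift lost in the scatter, and the second fluoro group contributes to the number. The same 4-fluorophenyl group also prints different numbers on the two cores, with compound 2 at 150 nM and compound 3 at 530 nM, but nothing among the data shown accounts for the step or for this difference.

The compounds shown leave open whether chloro, methyl or methoxy on this same carbon would keep the number near that of compound 1, or whether only fluoro does so. They also leave open how 2,4-difluorophenyl would read on the core of compound 2, so the size of this step is known on one core only.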